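The source may report more compounds than this note shows. Statements on the series, on what has been measured and on what is new or still open speak of the compounds shown alone.

The measurements come from an assay on isolated protein with malate dehydrogenase, mitochondrial (Sus scrofa) as the target; on this read-out higher numbers stand for weaker inhibition and lower numbers for stronger inhibition. Three compounds have been through it. Compound 1 `O=C(O)c1cnc2cc(OCc3c(Cl)c(Cl)c(Cl)c(Cl)c3Cl)ccc2c1O` carries a pentachlorobenzyl ether on the shared core and gives 4790 nM. Compound 2 `O=C(O)c1cnc2cc(OCCOc3ccccc3)ccc2c1O` carries a phenoxyethyl ether on the same core and gives 60300 nM. Compound 3 `O=C(O)c1ccc2c(O)c(C(=O)O)cnc2c1` is the bare core without any ether and gives 1070000 nM. Among these three numbers compound 2 stands second highest: the number for compound 1 lies well below it, beyond the usual scatter, and the number for compound 3 lies well above it, also beyond the scatter, so compound 2 sits between the two in this assay.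

Compound 4 `O=C(O)c1cnc2cc(OCCOc3ccc(F)cc3)ccc2c1O` is compound 2 with one change, fluoro in place of hydrogen on an aromatic carbon, para to a large group, or, read one bond further out, phenoxy to 4-fluorophenoxy. No measured pair among these compounds shows what such a swap does here, so no direction can be drawn from the data. A change of this small size is expected to shift the number little, most likely within the scatter, so the step from compound 2 to compound 4 is estimated at a 1.2-fold lower number from compound 2 to compound 4 (0.08 log units; within the scatter). For compound 4 the expected value is therefore 50000 nM, with a range from 15000 nM to 150000 nM.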

Compound 4, half-maximal inhibitory concentration: 18200 nM
The estimate for compound 4 lay 2.7-fold (0.44 log units) above the measured number, and the stated range covers the measured number.
By their numbers in this assay, from the lowest: compound 1; then compound 4; then compound 2; then compound 3.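

Replacing one hydrogen with fluoro on the aromatic carbon para to a large group, phenoxy to 4-fluorophenoxy, gives a step beyond the usual scatter, a 3.3-fold lower number from compound 2 to compound 4 (0.52 log units; beyond the scatter), though a modest one. Among the compounds shown here, this is the first comparison here in which only one place differs, and it shows that the number responds to a change at the outer end of the phenoxyethyl ether, even one of a single heavy atom. Nothing available explains why the number falls with this swap.

The compounds shown do not tell whether chloro, methyl or methoxy on the same carbon would move the number in the same direction, or by more or less. They also leave open whether a longer chain in the ether would shift it further.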